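One Aryl Swap on the Amide Nitrogen

The source may report more compounds than this note shows. Statements on the series, on what has been measured and on what is new or still open speak of the compounds shown alone.

In a functional assay on HT-29 cells (Homo sapiens) for cytotoxicity, read by MTT assay, with a stated time of 72 h (on this read-out higher numbers stand for weaker inhibition and lower numbers for stronger inhibition), compound 1 `O=C(CN1CCN(c2nnc(Cc3ccccc3)c3ccccc23)CC1)Nc1c(F)cccc1F` gives 19700 nM and compound 2 `Cc1ccc(F)cc1NC(=O)CN1CCN(c2nnc(Cc3ccccc3)c3ccccc23)CC1` gives 171000 nM, the higher of the two numbers. Compound 3 `COc1ccc(NC(=O)CN2CCN(c3nnc(Cc4ccccc4)c4ccccc34)CC2)cc1OC` keeps the shared core but carries 3,4-dimethoxyphenyl in place of 5-fluoro-2-methylphenyl on an amide-type nitrogen. Within the data shown here, the only measured step at this place is modest but beyond the scatter: an 8.7-fold higher number from compound 1 to compound 2 (0.94 log units; beyond the scatter). Neither measured compound carries the entering group, which leaves the direction uncertain, but with compound 2 at the top of this small range, a lower number seems likelier. The expected change is a 2.9-fold lower number from compound 2 to compound 3 (0.45 log units; beyond the scatter). Compound 3 is estimated at 60000 nM, within an expected range of 15000 nM to 200000 nM.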

Compound 3, half-maximal inhibitory concentration: 145000 nM
Beside the measured number, compound 3's estimate is 2.4-fold (0.38 log units) below it, and the stated range covers the measured number.
By their numbers in this assay, from the lowest: compound 1; then compounds 3 and 2 (each within the scatter of the next).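

In this assay, swapping 5-fluoro-2-methylphenyl for 3,4-dimethoxyphenyl on the amide-type nitrogen gives no readable change, despite the two hydrogen-bond acceptors that enter: a 1.2-fold lower number from compound 2 to compound 3 (0.07 log units; within the scatter). Compound 1 now stands apart from two differently substituted aryl groups, not just one, with a 7.4-fold higher number from compound 1 to compound 3 (0.87 log units; beyond the scatter). No measured evidence here explains this. Still open, from the compounds shown here alone, is how a pyridyl ring at this place would compare, or a phenyl ring carrying an amine or a carboxylic acid.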